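Working notes: cytotoxicity across three analogues of one series

A few compounds are considered here, and "the series" means these few. Any claim that something is new, unique, unknown or untested is made for them only; others in the source may bear on it.

Measured in an ADME assay on MT4 cells (Homo sapiens) for cytotoxicity, read by MTT assay; on this read-out lower numbers stand for higher toxicity in this test and higher numbers for lower toxicity in this test:
compound 1 `Cc1ccc(-c2c(C)nc(NC(=O)NC3CCCCC3)c(C)c2C(OC(C)(C)C)C(=O)O)cc1C` gives 7900 nM
compound 2 `COc1ccc(-c2c(C)nc(NC(=O)NC3CCCCC3)c(C)c2C(OC(C)(C)C)C(=O)O)cc1` gives 19000 nM

Among the measured compounds shown here, compound 1 stands at the lowest of the two numbers; the only measured step, a 2.4-fold higher number from compound 1 to compound 2 (0.38 log units; beyond the scatter), changes the aryl group, not the site altered below. Compound 3 `Cc1ccc(-c2c(C)nc(Nc3nc4ccccc4s3)c(C)c2C(OC(C)(C)C)C(=O)O)cc1C` differs from compound 1 by 1,3-benzothiazol-2-yl in place of cyclohexylcarbamoyl on a nitrogen on an aromatic ring. No measured step touches this position, so nothing shown bears on it, and the expected step of a 1.0-fold higher number from compound 1 to compound 3 (0.01 log units; within the scatter) is set near zero with a wide range. Compound 3 is therefore estimated at 8000 nM, between 2500 nM and 25000 nM.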

Compound 3, half-maximal cytotoxic concentration: 6600 nM
For compound 3 the middle estimate is 1.2-fold (0.08 log units) above the measured one; the range from low to high includes it.
By their numbers in this assay, from the lowest: compounds 3 and 1 (each within the scatter of the next); then compound 2.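

In this assay, 1,3-benzothiazol-2-yl in place of cyclohexylcarbamoyl gives a 1.2-fold lower number from compound 1 to compound 3 (0.08 log units; within the scatter). On a nitrogen on an aromatic ring, then, a six-membered non-aromatic ring of carbon and two aromatic rings cannot be told apart in this read-out, although the two groups differ in ring type and hetero atoms. No measured evidence on the reason for this is at hand.

From the compounds shown here alone, whether a much smaller group at this nitrogen, such as acetyl or a plain amine, would read the same stays open. So does whether 4-methoxyphenyl on the core of compound 3 would give a step like the one seen with the cyclohexylcarbamoyl group.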